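The compounds below may be only part of what the source reports. "The series", "measured", "known", "first", "only" and "open" are said of these compounds alone.

In a functional assay on NCI-H1975 cells (Homo sapiens) for inhibition, read by MTT assay, with a stated time of 72 h (on this read-out higher numbers stand for weaker inhibition and lower numbers for stronger inhibition), compound 1 `C=CC(=O)Nc1cccc(NC(=O)CSc2nc(Nc3cccc(Cl)c3)c3ccccc3n2)c1` gives 9460 nM, and compound 2 `C=CC(=O)Nc1cccc(NC(=O)CSc2nc(Nc3cccc(Br)c3)c3ccccc3n2)c1` gives 12100 nM. The one step between measured compounds, a 1.3-fold higher number from compound 1 to compound 2 (0.11 log units; within the scatter), is within the scatter, so on the two numbers shown compound 2 and compound 1 sit within the scatter of each other. Compound 3 `C=CC(=O)Nc1cccc(NC(=O)CSc2nc(Nc3cccc(OC)c3)c3ccccc3n2)c1` differs from compound 2 by methoxy in place of bromo on an aromatic carbon. Among the measured compounds shown here, the measured step at this position compared one halogen with another and gave nothing beyond the scatter; no measured step tells how a methoxy behaves at the same position, so the change is unanchored. With no evidence pointing either way, the expected step is a 1.1-fold lower number from compound 2 to compound 3 (0.04 log units; within the scatter), meaning no change beyond the scatter. Compound 3 is therefore estimated at 11000 nM, with a range from 4000 nM to 30000 nM that leaves room for a real shift in either direction.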

Compound 3, half-maximal inhibitory concentration: 7940 nM
Compound 3: middle estimate off by 1.4-fold (0.14 log units), on the high side; the measured number falls inside the stated range.
By their numbers in this assay, from the lowest: compounds 3, 1 and 2 (each within the scatter of the next).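

In this assay methoxy takes the place of bromo with a 1.5-fold lower number from compound 2 to compound 3 (0.18 log units; within the scatter) and takes the place of chloro with a 1.2-fold lower number from compound 1 to compound 3 (0.08 log units; within the scatter) and both steps lie within the scatter. The earlier compounds shown here compared only one halogen with another, whereas this change puts a group of two heavy atoms with one hydrogen-bond acceptor on the same aromatic carbon and still gives no difference beyond the scatter. No measurement is available that bears on this result.

Still open, going by these compounds, is whether an amine, a carboxylic acid or a longer chain such as ethoxy on this aromatic carbon would give a step beyond the scatter. Also open, on these data alone, is whether a change elsewhere on the shared core would move the number further than any change seen at this position.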